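Adding an Amino Group to the Acetyl of Compound 1

The compounds below may be only part of what the source reports. "The series", "measured", "known", "first", "only" and "open" are said of these compounds alone.

Going by the values given here, compound 1 `CC(=O)N1CCc2c(C)c3c(n2-c2ccc(C(N)=O)c(c2)N[C@@H](C)CC1)CC(C)(C)CC3=O` is the only member of this small set with a single number: in a functional assay on HCT-116 cells (Homo sapiens) for antiproliferative activity (on this read-out higher numbers stand for an effect only at larger amounts of compound and lower numbers for an effect already at smaller amounts), compound 1 gives 151 nM. Compound 3 `CC(=O)NCCN1CC[C@H](C)Nc2cc(ccc2C(N)=O)-n2c(c(C)c3c2CC(C)(C)CC3=O)CC1=O` is recorded in this assay as > 5000 nM, which is a limit of the assay rather than a number. Compound 2 `Cc1c2c(n3c1CC(=O)NCCCNc1cc-3ccc1C(N)=O)CC(C)(C)CC2=O` is recorded in this assay as "not determined" (no result reported), with no result reported. Compound 4 `Cc1c2c(n3c1CCN(C(=O)CN)CC[C@H](C)Nc1cc-3ccc1C(N)=O)CC(C)(C)CC2=O` differs from compound 1 in one place: amino in place of hydrogen on a saturated chain carbon bound to a carbonyl carbon. Among the compounds with values here, no measured pair in this set shows what such a change does, so the direction rests on general expectation only. Compound 4 is estimated at 250 nM in this assay, with a range from 60 nM to 1500 nM. The expected step is a 1.7-fold higher number from compound 1 to compound 4 (0.22 log units; within the scatter), small, likely within the scatter or slightly toward weaker activity.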

Compound 4, half-maximal effective concentration: 1010 nM
For compound 4 the middle estimate is 4.0-fold (0.61 log units) below the measured one; the range from low to high includes it.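

Going by these compounds alone, putting aminomethyl in place of methyl on the acetyl of compound 1 gives the only measured step at this position: in this assay it is a 6.7-fold higher number from compound 1 to compound 4 (0.83 log units; beyond the scatter) and lies beyond the usual scatter. This saturated chain carbon bound to a carbonyl carbon therefore responds to a single added amino group, and the response is toward weaker activity. Nothing shown accounts for the size of this step.

The compounds shown leave open how a hydroxyl group or a carboxylic acid in place of the amino group would read here. They also leave open whether a longer chain carrying the amine would give a different result.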